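A few compounds are considered here, and "the series" means these few. Any claim that something is new, unique, unknown or untested is made for them only; others in the source may bear on it.

Measured so far (a physicochemical assay for solubility, read by HPLC, in phosphate buffer, at pH 6.5; on this read-out higher numbers stand for higher solubility and lower numbers for lower solubility)
compound 1 `COC(=O)C1=C(C)NC(c2nccs2)=N[C@]1(C)c1ccc(F)cc1` gives 178 ug/mL
compound 2 `COC(=O)C1=C(C)NC(c2nccs2)=NC1(C)c1ccc(OC)cc1` gives 106 ug/mL
compound 3 `COC(=O)C1=C(CN2CCC(F)(F)CC2)NC(c2nccs2)=NC1(C)c1ccc(F)cc1` gives < 1 ug/mL

Compound 3 stands at the limit of < 1 ug/mL in this assay, at which 1 of the 3 values shown sits, and so has a limit and not a number. Compound 4 `COC(=O)C1=C(COCC(F)(F)F)NC(c2nccs2)=NC1(C)c1ccc(F)cc1` carries 2,2,2-trifluoroethoxy in place of 4,4-difluoropiperidin-1-yl on a saturated chain carbon bound to a double-bonded ring carbon. Among the compounds with values here, no measured step isolates this change. A modest rise in this assay is expected, with the estimated step being an at least 4.0-fold higher number from compound 3 to compound 4 (0.60 log units; beyond the scatter) as a rough guide. Compound 1 gives 178 ug/mL and compound 2 gives 106 ug/mL, and compound 4 is still expected to stay well under both of these values. The estimate for compound 4 is 4 ug/mL within an expected range from 1 ug/mL to 25 ug/mL for now.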

Compound 4, solubility: 19 ug/mL
Compound 4: middle estimate off by 4.8-fold (0.68 log units), on the low side, and the stated range covers the measured number.
By their numbers in this assay, from the lowest: compound 4; then compounds 2 and 1 (each within the scatter of the next). At a limit, below all of these: compound 3.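

Within the data shown here, this is the first step read at the saturated chain carbon bound to a double-bonded ring carbon, and it shows that the group held there can shift the read-out in this assay: 2,2,2-trifluoroethoxy in place of 4,4-difluoropiperidin-1-yl gives an at least 19-fold higher number from compound 3 to compound 4 (1.27 log units; beyond the scatter). As far as these compounds go, compound 3 stands at a limit and not a number, so the full size of the step stays unknown: the limit of < 1 ug/mL in this assay, at which 1 of the 4 values shown sits.

The swap removes the ring and the ring nitrogen and brings in the ether oxygen and a third fluorine at once, so no single part of the change can be singled out. From the compounds shown here alone, how morpholin-4-yl or a plain ethoxy group on the same carbon reads remains open.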